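Aminopyridine and pyridone nitriles with pendant aryl groups

The source may hold more compounds than are shown below. What is called first, only, known or untested is meant among the compounds shown, and "the series" means these compounds.

Measured compounds in a functional assay on BT-549 cells (Homo sapiens) for inhibition, read by sulforhodamine B assay, with a stated time of 48 h; on this read-out lower numbers stand for stronger inhibition of growth and higher numbers for weaker inhibition of growth:
- compound 1 `Cn1cccc1-c1cc(-c2cccs2)nc(N)c1C#N`: > 100000 nM
- compound 2 `Cn1cccc1-c1cc(-c2cccs2)[nH]c(=O)c1C#N`: > 100000 nM
- compound 3 `Cn1cccc1-c1cc(-c2ccccc2)[nH]c(=O)c1C#N`: 85100 nM

The value of compound 1 is a limit of the assay, not a number. The value of compound 2 is likewise a limit. Only compound 3 gives a numerical read-out in this assay, 85100 nM.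

The measured step in this assay is an at least 1.1-fold lower number from compound 2 to compound 3 (0.07 log units; that floor lies within the scatter), described as phenyl in place of thiophen-2-yl on an aromatic carbon. That step starts at the limit of > 100000 nM in this assay, at which 2 of the 3 values shown sit, so its size is a floor and not a measured distance.

Compound 4 `Cn1cccc1-c1cc(-c2ccccc2)nc(N)c1C#N` has not been measured. The change from compound 1 to compound 4 is phenyl in place of thiophen-2-yl on an aromatic carbon. Compared with the change from compound 2 to compound 3, the place line differs in one respect: in compound 1 the changed carbon is meta to an amino group (1 heavy atom), whereas in compound 2 it is meta to a group of 1 heavy atom. It is therefore the same kind of change, not the same change. How the cores of compound 1 and compound 2 differ is not broken down here.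

Among the measured compounds shown here, for compound 4 a step of about a number no higher from compound 1 to compound 4 (the limit leaves the size open) is expected, resting on the one observed step of the same kind, an at least 1.1-fold lower number from compound 2 to compound 3 (0.07 log units; that floor lies within the scatter), which itself only reaches the floor of the scatter. Since compound 1 sits at a limit, compound 4 is expected to lie near the same region, with a substantial chance that the assay again reports only a limit. The estimate for compound 4 in this assay is 100000 nM, within 40000 nM to 300000 nM.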

Compound 4, concentration for 50% growth inhibition: 60200 nM
Beside the measured number, compound 4's estimate is 1.7-fold (0.22 log units) above it; the range from low to high includes it.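

In this assay, phenyl in place of thiophen-2-yl on the core of compound 1 gives an at least 1.6-fold lower number from compound 1 to compound 4 (0.22 log units; that floor lies within the scatter), so the second core offers no sign that the change reverses, but the step itself does not clear the usual scatter. Both steps therefore point the same way only as floors, which makes the transfer of this change between the two cores compatible with the data without demonstrating it, and no size can be assigned to the change on either core: the same change on two cores in this assay, an at least 1.1-fold lower number (0.07 log units; that floor lies within the scatter) from compound 2 to compound 3 and an at least 1.6-fold lower number (0.22 log units; that floor lies within the scatter) from compound 1 to compound 4; the limit leaves it open whether they differ. Each of these steps starts from a value that is a limit and not a number, so neither gives a measured distance, and a shared size of the change remains unproven: the limit of > 100000 nM in this assay, at which 2 of the 4 values shown sit.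

Open, as far as these compounds go, is how other groups would read in the place of the phenyl, for example furan-2-yl, pyridin-2-yl or 4-fluorophenyl, and whether any of them would move the number clearly beyond the scatter. Also open, from the compounds shown here alone, are a carboxamide in place of the nitrile and an ethyl group in place of the methyl on the 1-methyl-1H-pyrrol-2-yl group, as well as what separates the core of compound 1 from the core of compound 2 when the pendant groups are held the same.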